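The source may hold more compounds than are shown below. What is called first, only, known or untested is meant among the compounds shown, and "the series" means these compounds.

Compound 1 `COc1cc(OC)c(C(=O)/C=C/c2ccccc2Cl)c(O)c1CN1CCCC1`: 6800 nM
Compound 2 `CCN(C)Cc1c(OC)cc(OC)c(C(=O)/C=C/c2ccccc2Cl)c1O`: 23300 nM

In a functional assay on Bel-7402 cells (Homo sapiens) for antiproliferative activity, with a stated time of 72 h (a lower number here means a stronger inhibitor, a higher number a weaker inhibitor), compound 2 gives 23300 nM, the higher of the two numbers measured. Compound 3 `CCN(CC)Cc1c(OC)cc(OC)c(C(=O)/C=C/c2ccccc2Cl)c1O` differs from compound 2 by methyl in place of hydrogen on a saturated chain carbon bound to an amine nitrogen. Among the measured compounds shown here, only one measured step bears on this, the modest 3.4-fold higher number from compound 1 to compound 2 (0.53 log units; beyond the scatter), and it reflects a different change, ethyl(methyl)amino in place of pyrrolidin-1-yl. It sets no size for this smaller change, so no shift beyond the scatter is expected. The expected step is a 1.2-fold lower number from compound 2 to compound 3 (0.07 log units; within the scatter). The estimated value for compound 3 is 20000 nM, within an expected range of 9000 nM to 45000 nM.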

Compound 3, half-maximal inhibitory concentration: 6700 nM
Compound 3: the middle estimate sits 3.0-fold (0.47 log units) above what was measured; measured number outside the range, below it.
By their numbers in this assay, from the lowest: compounds 3 and 1 (each within the scatter of the next); then compound 2.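

In this assay one added methyl on a saturated chain carbon bound to an amine nitrogen, turning ethyl(methyl)amino into diethylamino, gives a 3.5-fold lower number from compound 2 to compound 3 (0.54 log units; beyond the scatter) and so moves the number beyond the scatter. Diethylamino and pyrrolidin-1-yl cannot be told apart, with a 1.0-fold lower number from compound 1 to compound 3 (0.01 log units; within the scatter) and the two numbers inside the scatter. Nothing available accounts for the shift. From the compounds shown here alone, whether a longer chain on the amine nitrogen, as in dipropylamino, would keep this level stays open, as does the outcome for a piperidin-1-yl or morpholin-4-yl group.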